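The source may report more compounds than this note shows. Statements on the series, on what has been measured and on what is new or still open speak of the compounds shown alone.

The measured compounds in a functional assay on A498 cells (Homo sapiens) for inhibition, read by sulforhodamine B assay, with a stated time of 48 h; on this read-out lower numbers stand for higher toxicity in this test and higher numbers for lower toxicity in this test:

Compound 1 `COc1cc(-c2nn(-c3cccc(NC(=O)Nc4cc(C(F)(F)F)cc(C(F)(F)F)c4)c3)cc2-c2ccncc2)ccc1Cl`: 7140 nM
Compound 2 `COc1cc(-c2nn(-c3cccc(NC(=O)c4cccc(C(F)(F)F)c4)c3)cc2-c2ccncc2)ccc1Cl`: > 50000 nM, which is a limit of the assay and not a number
Compound 3 `O=C(Nc1cccc(-n2cc(-c3ccncc3)c(-c3ccc(Cl)c(O)c3)n2)c1)Nc1ccc(Cl)c(Cl)c1`: > 32500 nM, again a limit of the assay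

Compound 2 stands at the limit of > 50000 nM in this assay, at which 1 of the 3 values shown sits, so only a limit is known for it. Compound 3 stands at the limit of > 32500 nM in this assay, at which 1 of the 3 values shown sits, also a limit. Compound 1 alone gives a number in this assay.

Compound 4 `COc1cc(-c2nn(-c3cccc(NC(=O)Nc4cccc(C(F)(F)F)c4)c3)cc2-c2ccncc2)ccc1Cl` differs from compound 2 in one place: (3-(trifluoromethyl)phenyl)amino in place of 3-(trifluoromethyl)phenyl on a carbonyl carbon. For the measured compounds named here, no measured pair shows this change directly. Compound 1 carries an amino group on that carbonyl and gives a number in this assay, whereas compound 3, with an amino group on the carbonyl too, gives only a limit, so the two comparisons pull in different directions.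

The step from compound 2 to compound 4 is expected to move toward higher toxicity in this assay, with an estimated size of an at least 2.5-fold lower number from compound 2 to compound 4 (0.39 log units; beyond the scatter), beyond the usual scatter but short of what compound 1 reaches. Compound 4 is therefore estimated at 20000 nM, within a range from 6000 nM to 60000 nM.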

Compound 4, concentration lethal to 50% of the cells: > 50000 nM
Compound 4: a limit, no number; the forecaster's own chance of this, stated with the estimate: 40%; middle value at least 2.5-fold (0.39 log units) from the limit.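

In this assay, the change on the carbonyl carbon, (3-(trifluoromethyl)phenyl)amino in place of 3-(trifluoromethyl)phenyl, cannot be read, because compound 2 and compound 4 stand at the same limit of the assay: the limit of > 50000 nM in this assay, at which 2 of the 4 values shown sit.

For the compounds shown here, compound 4 does give the first single-place comparison with a measured number, as hydrogen in place of trifluoromethyl on an aromatic carbon gives an at least 7.0-fold higher number from compound 1 to compound 4 (0.84 log units; beyond the scatter). Among the compounds shown, the amino group on the carbonyl therefore does not by itself bring a number in this test, and the number for compound 1 goes with the second trifluoromethyl group on that ring.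

Going by these compounds, it remains open how far above the limit compound 2 and compound 4 lie, and whether the change on the carbonyl carbon would show a readable step if both trifluoromethyl groups of compound 1 were kept. On these data alone, it is also open how a nitrile or a carboxylic acid in place of that second trifluoromethyl group would fare in this assay.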